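The source may hold more compounds than are shown below. What is called first, only, known or untested is meant among the compounds shown, and "the series" means these compounds.

Compound 1 `CN1CCC=C(c2nc(N(C)C)no2)C1` gives 7.24 in a physicochemical assay for acid dissociation. Compound 2 `CN(C)c1noc(C2=CCCNC2)n1` carries hydrogen in place of methyl on an amine nitrogen in a ring, the change (hydrogen in place of methyl on an amine nitrogen in a ring), and in this assay compound 2 gives 8.58, so the step of a number 1.34 log units higher from compound 1 to compound 2 (beyond the scatter) is large. Compound 3 `Cc1noc(C2=CCC(C)N(C)C2)n1` gives 7.35 in this assay; the difference between its core and the core of compound 1 is not broken down here. Compound 4 `Cc1noc(C2=CCC(C)NC2)n1` is related to compound 3 by the same kind of change, (hydrogen in place of methyl on an amine nitrogen in a ring), though here the amine nitrogen sits next to the ring atom that bears a methyl group and two ring bonds from a group of 6 heavy atoms rather than 8. Because the matched step a number 1.34 log units higher from compound 1 to compound 2 (beyond the scatter) was large, a step of similar size, a number 1.25 log units higher from compound 3 to compound 4 (beyond the scatter), is expected. Compound 4 is therefore estimated to give 8.6 in this assay, most likely between 8.2 and 9.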

Compound 4, acid dissociation constant: 8.2
For compound 4 the middle estimate is 0.40 log units above the measured one; the range from low to high includes it.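

In this assay the change to hydrogen in place of methyl on an amine nitrogen in a ring again gives a higher number, with a number 0.85 log units higher from compound 3 to compound 4 (beyond the scatter) being modest where a number 1.34 log units higher from compound 1 to compound 2 (beyond the scatter) was large. The direction thus carries from one core to the other in the two pairs shown, but the size of the step does not carry over unchanged. No measurement shown here bears on why the size differs between the two cores.

The compounds shown leave open what an ethyl or an acetyl group in place of that methyl on the amine nitrogen would give. They also leave open how the step would read on the core of compound 3 without its ring methyl group.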